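A few compounds are considered here, and "the series" means these few. Any claim that something is new, unique, unknown or untested is made for them only; others in the source may bear on it.

Compound 1 `COc1ccc(-c2ccnc(Nc3ccc([N+](=O)[O-])cc3)n2)cc1` is the strongest of the three compounds measured in a functional assay on HepG2 cells (Homo sapiens) for antiproliferative activity, read by MTT assay (a higher number here means a weaker inhibitor, a lower number a stronger inhibitor), where compound 1 gives 1040 nM. Compound 2 `O=[N+]([O-])c1ccc(Nc2nccc(-c3ccc(Br)cc3)n2)cc1` differs from it by bromo in place of methoxy on an aromatic carbon, and in this assay compound 2 gives 43000 nM; the step is a 41-fold higher number from compound 1 to compound 2 (1.62 log units; beyond the scatter). Compound 3 `COc1ccc(-c2ccnc(Nc3cccc(OC)c3)n2)cc1` has a different core from compound 1, and the difference between the two cores is not broken down here; in this assay compound 3 gives 13900 nM, a number that stands between those of the other two compounds. Compound 4 `COc1cccc(Nc2nccc(-c3ccc(Br)cc3)n2)c1` has not yet been measured and differs from compound 3 by bromo in place of methoxy on an aromatic carbon, the same change that separates compound 1 from compound 2, made at the same place. Because the earlier instance of this change gave a 41-fold higher number from compound 1 to compound 2 (1.62 log units; beyond the scatter), a large weakening is expected here as well, an 8.6-fold higher number from compound 3 to compound 4 (0.94 log units; beyond the scatter). It is expected to be somewhat smaller than the earlier step, since compound 3 already starts from 13900 nM. For compound 4 the estimate in this assay is 120000 nM, with a likely range from 30000 nM to 450000 nM.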

Compound 4, half-maximal inhibitory concentration: 148000 nM
Estimate against measurement, compound 4: 1.2-fold (0.09 log units) below, within the range that was stated.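

In this assay, replacing methoxy with bromo again gives a weaker compound, with an 11-fold higher number from compound 3 to compound 4 (1.03 log units; beyond the scatter), so the direction of the change carries over from the core of compound 1 to the core of compound 3. Its size does not carry over unchanged, and the step is clearly larger on the core of compound 1: the same change on two cores in this assay, a 41-fold higher number (1.62 log units; beyond the scatter) from compound 1 to compound 2 and an 11-fold higher number (1.03 log units; beyond the scatter) from compound 3 to compound 4, 3.9-fold (0.59 log units) apart, beyond the scatter of two such steps. With only two instances, this shows that the direction held in both pairs but establishes no rule for the series, and the data do not explain why the size of the step depends on the core.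

The compounds shown have only methoxy or bromo at this place, so it remains open whether chloro, an amine or a carboxylic acid would lie closer to methoxy or to bromo. As far as these compounds go, it is also open how the step would behave on a core carrying something other than the nitro or methoxy group that separates these two cores, such as a longer chain.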